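The source may hold more compounds than are shown below. What is called first, only, known or untested is meant among the compounds shown, and "the series" means these compounds.

Measured so far:
compound 1 `CCCCCN(CCCCC)C(=O)N1CCN(C(=O)N(c2ccccc2)c2ccccc2)[C@H](C(=O)O)C1` — 130 nM
compound 2 `CCCCCN(CCCCC)C(=O)N1CCN(C(=O)N(c2ccccc2)c2ccccc2)[C@H](C(=O)NCCN(CC)CC)C1` — 11 nM

In an assay on CHO cells for binding affinity to Substance-P receptor (Homo sapiens) (a higher number here means a weaker inhibitor, a lower number a stronger inhibitor), compound 1 gives 130 nM and compound 2 gives 11 nM. Within the data shown here, compound 2 stands lowest of the two numbers in this assay; its nearest neighbour is compound 1, and the step from one to the other is a 12-fold lower number from compound 1 to compound 2 (1.07 log units; beyond the scatter), the only measured step.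

Compound 3 `CCCCCN(CCCCC)C(=O)N1CCN(C(=O)N(c2ccccc2)c2ccccc2)[C@H](C(=O)NCCN(C)Cc2ccccc2OC)C1` is not yet measured. It differs from compound 2 in one place: (2-methoxybenzyl)(methyl)amino in place of diethylamino on a saturated chain carbon, two bonds along the chain from an amide-type nitrogen. Among the measured compounds shown here, the one step that bears on it, a 12-fold lower number from compound 1 to compound 2 (1.07 log units; beyond the scatter), shows that what sits on the carbonyl carbon of the core matters a great deal in this assay, but it compares an acid with a basic side chain and says nothing about exchanging one tertiary amine for another at the end of that chain. Both compound 2 and compound 3 keep the amide linkage and a tertiary amine two bonds along the chain from the amide-type nitrogen, so no step beyond the scatter is expected in either direction. Compound 3 is therefore estimated at 10 nM, within 3 nM to 40 nM, which would mean a step of a 1.1-fold lower number from compound 2 to compound 3 (0.04 log units; within the scatter).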

Compound 3, half-maximal inhibitory concentration: 9 nM
Compound 3: the middle estimate sits 1.1-fold (0.05 log units) above what was measured, and the stated range covers the measured number.
By their numbers in this assay, from the lowest: compounds 3 and 2 (each within the scatter of the next); then compound 1.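

In this assay, (2-methoxybenzyl)(methyl)amino in place of diethylamino gives a 1.2-fold lower number from compound 2 to compound 3 (0.09 log units; within the scatter), so at this saturated chain carbon, two bonds along the chain from an amide-type nitrogen, a group of 11 heavy atoms with a six-membered aromatic ring stands in for one of 5 heavy atoms with no ring, with no step beyond the scatter. The earlier step, a 12-fold lower number from compound 1 to compound 2 (1.07 log units; beyond the scatter), concerned the group on the carbonyl carbon and gave no reading on the far end of the chain, whereas this pair shows two different tertiary amines there that cannot be told apart in this assay. No supporting data bear on the reason for this result.

The compounds shown change the methoxy group, the aromatic ring and the methyl on the amine together, so a plain benzyl group on the same nitrogen would be needed to read the methoxy group on its own. Also open, on these data alone, is how this position responds to a secondary amine, a piperidine or a longer chain leading to the amine.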